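A few compounds are considered here, and "the series" means these few. Any claim that something is new, unique, unknown or untested is made for them only; others in the source may bear on it.

The measured compounds in a functional assay on CCRF-CEM cells (Homo sapiens) for inhibition (on this read-out lower numbers stand for stronger inhibition and higher numbers for weaker inhibition), are:

compound 1, `Cc1ccsc1-c1ncnc2c1ncn2C1O[C@H](CO)[C@@H](O)[C@H]1O`, giving 2500 nM
compound 2, `OC[C@H]1OC(n2cnc3c(-c4nccs4)ncnc32)[C@H](O)[C@@H]1O`, giving 2730 nM
compound 3, `OC[C@H]1OC(n2cnc3c(-c4ccccn4)ncnc32)[C@H](O)[C@@H]1O`, giving 900 nM

On these numbers compound 3 stands lowest of the three; the steps to it, a 2.8-fold lower number from compound 1 to compound 3 (0.44 log units; beyond the scatter) and a 3.0-fold lower number from compound 2 to compound 3 (0.48 log units; beyond the scatter), both lie beyond the scatter, while compounds 1 and 2 sit within the scatter of each other, as a 1.1-fold higher number from compound 1 to compound 2 (0.04 log units; within the scatter) shows. Compound 4, `OC[C@H]1OC(n2cnc3c(-c4ccsc4)ncnc32)[C@H](O)[C@@H]1O`, is not yet measured. It differs from compound 3 in one place: thiophen-3-yl in place of pyridin-2-yl on an aromatic carbon. Going by the values given here, the steps that bear on this change are those from compound 1 and compound 2 to compound 3, where a five-membered ring with one sulfur or with sulfur and nitrogen was replaced by pyridin-2-yl and the number fell modestly. Since compound 4 again carries a five-membered ring with one sulfur, a modest rise in this assay relative to compound 3 is expected, a 2.2-fold higher number from compound 3 to compound 4 (0.35 log units; beyond the scatter). Compound 4 is therefore estimated at 2000 nM, within a range of 800 nM to 5000 nM.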

Compound 4, half-maximal inhibitory concentration: 1640 nM
The estimate for compound 4 lay 1.2-fold (0.09 log units) above the measured number; measured number inside the range.
By their numbers in this assay, from the lowest: compounds 3, 4, 1 and 2 (each within the scatter of the next, the first and the last beyond it).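

In this assay, thiophen-3-yl at this aromatic carbon does not clearly part from pyridin-2-yl, with a 1.8-fold higher number from compound 3 to compound 4 (0.26 log units; within the scatter) as the step. Compound 4 also lies within the scatter of both other five-membered rings, through a 1.7-fold lower number from compound 2 to compound 4 (0.22 log units; within the scatter) and a 1.5-fold lower number from compound 1 to compound 4 (0.18 log units; within the scatter) as its steps, so the clear gap that separated pyridin-2-yl from compounds 1 and 2 does not hold for every sulfur-bearing five-membered ring, and these four groups now form an overlapping run rather than two separate sets. No measured evidence on these compounds speaks to why the numbers fall this way.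

Going by these compounds, how an amine, a methoxy group or a plain phenyl ring would read at this aromatic carbon stays open. So does the part played by the methyl group of compound 1, which thiophen-2-yl without that methyl group would address.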